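Replacing the amide linker with a fused naphthalene ring

A few compounds are considered here, and "the series" means these few. Any claim that something is new, unique, unknown or untested is made for them only; others in the source may bear on it.

Three compounds share one core and differ only in the group attached to a saturated chain carbon bound to an oxygen on an unsaturated carbon. In a functional assay on thoracic aorta for inhibition of Voltage-gated L-type calcium channel (Rattus norvegicus) (on this read-out higher numbers stand for weaker inhibition and lower numbers for stronger inhibition), compound 1 `CC1=NC(C)=C(C(=O)O)C(c2cccc(Cl)c2)/C1=C(\O)OC/C=C/c1ccncc1` gives 320 nM, compound 2 `CC1=NC(C)=C(C(=O)O)C(c2cccc(Cl)c2)/C1=C(\O)OC/C(C)=C/c1ccccc1` gives 2.8 nM, and compound 3 `CC1=NC(C)=C(C(=O)O)C(c2cccc(Cl)c2)/C1=C(\O)OCC(=O)Nc1ccccc1` gives 50 nM. Compound 3 thus stands second highest of the three, with a 6.4-fold lower number from compound 1 to compound 3 (0.81 log units; beyond the scatter) and an 18-fold higher number from compound 2 to compound 3 (1.25 log units; beyond the scatter).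

Compound 4 `CC1=NC(C)=C(C(=O)O)C(c2cccc(Cl)c2)/C1=C(\O)OCc1ccc2ccccc2c1` is formed from compound 3 by the change (naphthalen-2-yl in place of phenylcarbamoyl on a saturated chain carbon bound to an oxygen on an unsaturated carbon). Within the data shown here, two measured steps bear on it. The step of an 18-fold higher number from compound 2 to compound 3 (1.25 log units; beyond the scatter) shows that exchanging the phenylcarbamoyl group for a carbon-only unsaturated group gave a large move to lower numbers, whereas a 6.4-fold lower number from compound 1 to compound 3 (0.81 log units; beyond the scatter) shows that a pyridine-bearing group sat higher still. Naphthalen-2-yl, like the group in compound 2, carries only carbon, so a step toward lower numbers is expected in this assay, though its exact size is uncertain.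

Compound 4 is therefore estimated at 10 nM, within a range of 2 nM to 50 nM, which corresponds to an expected step of a 5.0-fold lower number from compound 3 to compound 4 (0.70 log units; beyond the scatter).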

Compound 4, half-maximal inhibitory concentration: 14 nM
For compound 4 the middle estimate is 1.4-fold (0.15 log units) below the measured one, and the stated range covers the measured number.
By their numbers in this assay, from the lowest: compound 2; then compound 4; then compound 3; then compound 1.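

In this assay, naphthalen-2-yl, which has two six-membered aromatic rings of carbon only and no hydrogen-bond donor or acceptor, gives a lower number than phenylcarbamoyl at this place (a 3.6-fold lower number from compound 3 to compound 4 (0.55 log units; beyond the scatter)), so the amide is not needed for a low number here. Carbon-only groups still differ from one another, as naphthalen-2-yl falls short of 1-methyl-2-phenylethenyl (a 5.0-fold higher number from compound 2 to compound 4 (0.70 log units; beyond the scatter)), yet it stands well clear of 2-(pyridin-4-yl)ethenyl (a 23-fold lower number from compound 1 to compound 4 (1.36 log units; beyond the scatter)). Nothing measured here explains these differences.

This change removes the amide and adds a second ring in one step, so the two effects cannot be separated without a plain phenyl group at this place. From the compounds shown here alone, how naphthalen-1-yl, or naphthalen-2-yl carrying an amine or a carboxylic acid, would behave also remains open.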